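Cyano for methoxy on the sulfonyl aryl ring

The compounds below may be only part of what the source reports. "The series", "measured", "known", "first", "only" and "open" are said of these compounds alone.

Compound 1 `O=C(c1ccc(OCCCN2CC[C@H](NS(=O)(=O)c3cccc(F)c3)C2)cc1)C1CC1` gives 1600 nM in an assay on isolated protein for binding affinity to histamine H2 receptor (Homo sapiens); a lower number here means a stronger inhibitor, a higher number a weaker inhibitor. Compound 2 `O=C(c1ccc(OCCCN2CC[C@H](NS(=O)(=O)c3ccc(F)cc3)C2)cc1)C1CC1` gives 500 nM in this assay. Compound 3 `COc1ccc(S(=O)(=O)N[C@H]2CCN(CCCOc3ccc(C(=O)C4CC4)cc3)C2)cc1` gives 1000 nM in this assay.

Compound 3 stands second highest of the three numbers; its gap to compound 1 and to compound 2 both lie within the scatter, so no order among the three is secure apart from a 3.2-fold lower number from compound 1 to compound 2 (0.51 log units; beyond the scatter). Compound 4 `N#Cc1ccc(S(=O)(=O)N[C@H]2CCN(CCCOc3ccc(C(=O)C4CC4)cc3)C2)cc1` carries the change (cyano in place of methoxy on an aromatic carbon).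

For the measured compounds named here, two measured steps touch the same position on the sulfonyl aryl ring. a 2.0-fold higher number from compound 2 to compound 3 (0.30 log units; within the scatter), within the scatter. a 3.2-fold lower number from compound 1 to compound 2 (0.51 log units; beyond the scatter), a modest gain. Going by the values given here, no measured compound carries a cyano group, so the new group itself has no precedent here; the only guide is that the one exchange made at this position so far stayed within the scatter. For compound 4 the step is therefore expected to be small, a 1.3-fold lower number from compound 3 to compound 4 (0.10 log units; within the scatter), with no direction beyond the scatter. Compound 4 is estimated at 800 nM, in the range 250 nM to 2500 nM.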

Compound 4, inhibition constant: 1600 nM
Estimate against measurement, compound 4: 2.0-fold (0.30 log units) below; low and high end bracket the measured number.
By their numbers in this assay, from the lowest: compounds 2, 3, 1 and 4 (each within the scatter of the next, the first and the last beyond it).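

The nitrile does not separate from methoxy on the sulfonyl aryl ring, with a 1.6-fold higher number from compound 3 to compound 4 (0.20 log units; within the scatter), and the 4-cyanophenyl compound also matches the 3-fluorophenyl compound, with no change at the digits printed from compound 1 to compound 4 (within the scatter). The step of a 3.2-fold higher number from compound 2 to compound 4 (0.51 log units; beyond the scatter) gives the series its second exchange beyond the scatter, so 4-fluorophenyl now stands clear of both 3-fluorophenyl and 4-cyanophenyl, while 4-methoxyphenyl stays within the scatter of all three. No evidence on the origin of these differences is available.

As far as these compounds go, it remains open how an amine or a carboxylic acid on the same aromatic carbon would read in this assay. Also open, from the compounds shown here alone, is whether the advantage of 4-fluorophenyl over 4-cyanophenyl would persist with a longer chain in the shared core.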